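A few compounds are considered here, and "the series" means these few. Any claim that something is new, unique, unknown or untested is made for them only; others in the source may bear on it.

Measured so far in an assay on isolated protein for inhibition of fatty acid synthase (Mus musculus), read by spectrophotometry, using NADPH, with stated times of 30 min and 3 min, in the presence of a further agent that is not named here; on this read-out lower numbers stand for stronger inhibition and higher numbers for weaker inhibition:

compound 1, `CC(=O)O[C@H]1C(=O)OCC1(C)C`: 33200 nM
compound 2, `CCCCCC(=O)O[C@H]1C(=O)OCC1(C)C`: 23300 nM
compound 3, `CCCCCCCC(=O)O[C@H]1C(=O)OCC1(C)C`: 20800 nM

Compound 3 carries the lowest of the three numbers, but its separation from compound 2 is only a 1.1-fold lower number from compound 2 to compound 3 (0.05 log units; within the scatter) and from compound 1 only a 1.6-fold lower number from compound 1 to compound 3 (0.20 log units; within the scatter), both within the scatter, so the three are not ranked by these data.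

Compound 4, `CCCCCCCCCCCC(=O)O[C@H]1C(=O)OCC1(C)C`, is not yet measured. It differs from compound 3 by butyl in place of hydrogen on a saturated chain carbon, seven bonds along the chain from a carbonyl carbon, a further extension of the same acyl chain. For the measured compounds named here, the steps that bear on it are the chain lengthenings already made: a 1.4-fold lower number from compound 1 to compound 2 (0.15 log units; within the scatter) and a 1.1-fold lower number from compound 2 to compound 3 (0.05 log units; within the scatter). Each lengthening of the chain moved the number a little lower, but never beyond the scatter. The move from compound 3 to compound 4 is therefore expected to be of the same kind, a small lowering or none at all in this assay, estimated as a 1.2-fold lower number from compound 3 to compound 4 (0.09 log units; within the scatter).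

Compound 4 is estimated at 17000 nM, with a range from 7000 nM to 40000 nM.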

Compound 4, half-maximal inhibitory concentration: 15200 nM
Estimate against measurement, compound 4: 1.1-fold (0.05 log units) above; measured number inside the range.
By their numbers in this assay, from the lowest: compounds 4, 3, 2 and 1 (each within the scatter of the next, the first and the last beyond it).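

In this assay, butyl in place of hydrogen, seven bonds along the chain from a carbonyl carbon, gives a 1.4-fold lower number from compound 3 to compound 4 (0.14 log units; within the scatter), and hexyl in place of hydrogen, five bonds along the chain, gives a 1.5-fold lower number from compound 2 to compound 4 (0.19 log units; within the scatter). New with compound 4 is that the two ends of the series stand apart beyond the scatter, compound 1 at 33200 nM and compound 4 at 15200 nM, while each compound remains within the scatter of the next. The butyl change gives much the same step far out on the chain as on the core of compound 1: the same change on two cores in this assay, a 1.4-fold lower number (0.15 log units; within the scatter) from compound 1 to compound 2 and a 1.4-fold lower number (0.14 log units; within the scatter) from compound 3 to compound 4, 1.0-fold (0.02 log units) apart, within the scatter of two such steps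

On these data alone, whether a longer chain would separate from compound 4 beyond the scatter stays open. So does the effect of a carboxylic acid or an amine carried on the acyl chain in place of a plain carbon chain.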